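The compounds below may be only part of what the source reports. "The series", "measured", "known", "first", "only" and "open" are said of these compounds alone.

In a functional assay on HCT-116 cells (Homo sapiens) for cytotoxicity, read by MTT assay, with a stated time of 72 h (a lower number here means a stronger inhibitor, a higher number a weaker inhibitor), compound 1 `Nc1ccccc1NC(=O)c1ccc(NC(=S)NCc2cccc(F)c2)cc1` gives 5900 nM and compound 2 `Nc1ccccc1NC(=O)c1ccc(NC(=S)NCc2ccccc2F)cc1` gives 6300 nM, so compound 2 stands level with compound 1 within the scatter. Compound 3 `Nc1ccccc1NC(=O)c1ccc(Cn2cc(-c3ccc(NC(=O)NCc4cccnc4)cc3)nn2)cc1` gives > 100000 nM, which is a limit of the assay and not a number. The next step leads from compound 2 to compound 4 `Nc1ccccc1NC(=O)c1ccc(NC(=S)NCc2cccc(Cl)c2)cc1`, and the change is 3-chlorophenyl in place of 2-fluorophenyl on a saturated chain carbon bound to an amide-type nitrogen. Going by the values given here, only one measured step bears on this: a 1.1-fold higher number from compound 1 to compound 2 (0.03 log units; within the scatter), where 2-fluorophenyl stands in place of 3-fluorophenyl. Among the compounds with values here, no measured step exchanges fluorine for chlorine, so the expectation rests on that single small step and remains uncertain. No change beyond the scatter is therefore expected in this assay, and the estimated step is a 1.3-fold lower number from compound 2 to compound 4 (0.10 log units; within the scatter). Compound 4 is expected at 5000 nM, with an estimated range of 2000 nM to 12000 nM.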

Compound 4, half-maximal inhibitory concentration: 5900 nM
Beside the measured number, compound 4's estimate is 1.2-fold (0.07 log units) below it; low and high end bracket the measured number.
By their numbers in this assay, from the lowest: compounds 1, 4 and 2 (each within the scatter of the next). At a limit, above all of these: compound 3.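

In this assay, the exchange on the saturated chain carbon bound to an amide-type nitrogen gives a 1.1-fold lower number from compound 2 to compound 4 (0.03 log units; within the scatter), so 3-chlorophenyl and 2-fluorophenyl cannot be told apart at this place. The earlier compounds shown here varied only where the fluoro group sits, whereas compound 4 also changes the halogen itself: with the ring position held, chloro in place of fluoro on an aromatic carbon gives no change at the digits printed from compound 1 to compound 4 (within the scatter). Nothing available here accounts for these flat steps.

The compounds shown leave open whether an amine, a carboxylic acid or a methoxy group on this phenyl ring, or a longer chain in place of the benzyl group, would move the number beyond the scatter. They also leave open how 2-chlorophenyl would compare at this place.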